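Adding chlorine to the compound with the highest number among three pyrimidine amines

A few compounds are considered here, and "the series" means these few. Any claim that something is new, unique, unknown or untested is made for them only; others in the source may bear on it.

Of the compounds shown here, three sharing one core have been tested in an assay on CHO cells for displacement of a labelled ligand from adenosine receptor A1 (Homo sapiens), read by scintillation counting, with a stated time of 1 h, tested at 1 uM; a lower number here means less inhibition, a higher number more inhibition at the concentration tested (going by the name of the read-out). Compound 1 `Nc1ncc(-c2ccccc2)c(-c2ccccc2)n1` gives 32%. Compound 2 `Nc1ncc(-c2ccc(Cl)cc2)c(-c2ccccc2)n1` gives 41%, and the step of a number 9 percentage points higher from compound 1 to compound 2 (within the scatter). Compound 3 `COc1ccc(-c2cnc(N)nc2-c2ccccc2)cc1` gives 56%; the step of a number 24 percentage points higher from compound 1 to compound 3 (beyond the scatter), and the step of a number 15 percentage points higher from compound 2 to compound 3 (beyond the scatter). Compound 3 therefore stands highest of the three numbers, and its advantage over both compound 2 and compound 1 lies beyond the scatter of this assay.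

The next compound, compound 4 `COc1ccc(-c2cnc(N)nc2-c2ccccc2)cc1Cl`, keeps everything of compound 3 and differs in one place: chloro in place of hydrogen on an aromatic carbon. Among the compounds with values here, one measured step bears directly on this kind of change, the step of a number 9 percentage points higher from compound 1 to compound 2 (within the scatter), where the same exchange of a hydrogen for a chloro group on an aromatic carbon was made on the other ring. That step stayed within the scatter, so a chloro group on this core has so far not moved the read-out by a clear amount.

On that basis the step of a number 4 percentage points higher from compound 3 to compound 4 (within the scatter) is expected to be small, perhaps slightly upward but not clearly beyond the scatter. Compound 4 is therefore estimated to give 60% in this assay, with a range from 45% to 75%.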

Compound 4, a percentage reported as inhibition, at one concentration (the size of the read-out at that concentration, not a potency): > 80%
Compound 4 ended at the assay's limit (the forecaster's own chance of this, stated with the estimate: 0%); middle value at least 20 percentage points from the limit.
By their numbers in this assay, from the lowest: compounds 1 and 2 (each within the scatter of the next); then compound 3. At a limit, above all of these: compound 4.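

In this assay, a chloro group on an aromatic carbon ortho to a methoxy group brings a clear rise, the step being a number at least 24 percentage points higher from compound 3 to compound 4 (beyond the scatter). The earlier compounds gave no sign of a rise of this size, and the new result shows that the same exchange of hydrogen for chloro does not have one fixed size across this series: the same change on two cores in this assay, a number 9 percentage points higher (within the scatter) from compound 1 to compound 2 and a number at least 24 percentage points higher (beyond the scatter) from compound 3 to compound 4, at least 15 percentage points apart, beyond the scatter of two such steps Compound 4 gives > 80%, which is a limit of the assay and not a number: the limit of > 80% in this assay, at which 1 of the 4 values shown sits.

How far compound 4 lies past that limit remains open, so the step has a lower bound but no exact size, and a single-concentration read-out gives no potency for any of these compounds. On these data alone, it also remains open whether the rise depends on chlorine itself and on the methoxy group being present, or whether a fluoro group, a methyl group, an amine or a carboxylic acid at the same place would produce a similar step.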